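Methyl ester to free acid on a hexokinase-1 inhibitor

This account rests on a few compounds, and the source may have more. Where it says the series, first, only, none or still open, it means among the compounds named here.

Compound 1 `COC(=O)c1cc(S(=O)(=O)NC[C@H]2OC(O)[C@H](NC(=O)c3cccc(Br)c3)[C@@H](O)[C@@H]2O)oc1C` was measured in an assay for inhibition of hexokinase-1 (Homo sapiens), read by ADP-Glo, with a stated time of 45 min, in the presence of a further agent that is not named here (a higher number here means a weaker inhibitor, a lower number a stronger inhibitor), where compound 1 gives 1600 nM. Going by the values given here, its only companion is compound 2 `O=S(=O)(N[C@H]1C(O)O[C@H](CNS(=O)(=O)c2cccc(Cl)c2Cl)[C@@H](O)[C@@H]1O)c1cccc(-c2ccc(Cl)cc2)c1`, which in this assay gives 1000 nM; the two numbers lie within the usual scatter of each other, so compound 1 stands level with compound 2. Compound 3 `Cc1oc(S(=O)(=O)NC[C@H]2OC(O)[C@H](NC(=O)c3cccc(Br)c3)[C@@H](O)[C@@H]2O)cc1C(=O)O` differs from compound 1 by hydrogen in place of methyl on an oxygen next to a carbonyl group. Among the compounds with values here, no comparable step has been measured here, so a step of no change at the digits printed from compound 1 to compound 3 (within the scatter) is expected, none beyond the scatter. Compound 3 is estimated at 1600 nM, within 500 nM to 5000 nM.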

Compound 3, half-maximal inhibitory concentration: 20 nM
The estimate for compound 3 lay 80-fold (1.90 log units) above the measured number; the measured number lies below the stated range.
By their numbers in this assay, from the lowest: compound 3; then compounds 2 and 1 (each within the scatter of the next).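

Going from methoxycarbonyl to carboxy gives an 80-fold lower number from compound 1 to compound 3 (1.90 log units; beyond the scatter) in this assay and shows that this single place on the core of compound 1 has a strong bearing on the read-out. The earlier compounds shown here, level with each other and differing in more than one place, could not show this. Nothing available here says what lies behind the step. From the compounds shown here alone, it remains open whether the carboxylic acid itself is needed, or whether a primary amide, a tetrazole or an acid on a longer chain would serve equally. Going by these compounds, whether the step holds when the rest of the molecule changes is also open.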